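The source may report more compounds than this note shows. Statements on the series, on what has been measured and on what is new or still open speak of the compounds shown alone.

Measured compounds:
compound 1 `CC1=NN(C(=O)c2ccc([N+](=O)[O-])cc2)C(c2ccccc2O)C1` gives 50000 nM
compound 2 `CC1=NN(C(=O)CCc2ccccc2)C(c2cc(Br)cc(Br)c2O)C1` gives 17100 nM
compound 3 `CCCNCC(=O)N1N=C(c2cc3ccccc3oc2=O)CC1c1ccccc1` gives 4880 nM

In a functional assay on MGC-803 cells (Homo sapiens) for cytotoxicity, read by MTT assay, with a stated time of 48 h (on this read-out lower numbers stand for stronger inhibition and higher numbers for weaker inhibition), compound 3 stands lowest of the three numbers; its gap to compound 2 and its larger gap to compound 1 both lie beyond the scatter of repeated measurements. Compound 4 `CCN(CC)C1CCN(CC(=O)N2N=C(c3cc4ccccc4oc3=O)CC2c2ccccc2)CC1` shares the core of compound 3 and differs from it in one place: 4-(diethylamino)piperidin-1-yl in place of propylamino on a saturated chain carbon bound to a carbonyl carbon. For the measured compounds named here, no step between two measured compounds that differ in one place is available to calibrate this change. The step from compound 3 to compound 4 is therefore expected to be small, a 1.4-fold lower number from compound 3 to compound 4 (0.14 log units; within the scatter), most likely within the scatter or a modest move to a lower number. Compound 4 is accordingly estimated at 3500 nM, within a range of 1200 nM to 10000 nM.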

Compound 4, half-maximal inhibitory concentration: 32400 nM
Compound 4: the middle estimate sits 9.3-fold (0.97 log units) below what was measured; the measured number lies above the stated range.
By their numbers in this assay, from the lowest: compound 3; then compounds 2, 4 and 1 (each within the scatter of the next, the first and the last beyond it).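

In this assay, putting 4-(diethylamino)piperidin-1-yl in place of propylamino on a saturated chain carbon bound to a carbonyl carbon gives a 6.6-fold higher number from compound 3 to compound 4 (0.82 log units; beyond the scatter), the first step read at this position. The position is therefore sensitive to which amine it carries: the larger group, with its ring and without a hydrogen-bond donor, goes with the weaker number. Nothing measured here explains the step. Going by these compounds, whether the size, the ring or the missing donor matters stays open, since this single step changes all three together. A dimethylamino group, a morpholine ring or a longer alkyl chain on that carbon would help to separate them.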